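Swapping chloro for trifluoromethyl in a cytotoxicity series

The source may hold more compounds than are shown below. What is called first, only, known or untested is meant among the compounds shown, and "the series" means these compounds.

Compound 1 `CN1C/C(=C\c2ccc(C(F)(F)F)cc2)C(=O)/C(=C/c2ccccc2F)C1`: 6340 nM
Compound 2 `CN1C/C(=C\c2ccc(Cl)cc2)C(=O)/C(=C/c2cccc([N+](=O)[O-])c2)C1`: > 20000 nM

Both compounds were tested in a functional assay on K562 cells (Homo sapiens) for cytotoxicity, read by MTT assay, with a stated time of 24 h; a lower number here means a stronger inhibitor, a higher number a weaker inhibitor. The entry for compound 2, > 20000 nM, is a limit of the assay and not a number. Compound 3 `CN1C/C(=C\c2ccc(C(F)(F)F)cc2)C(=O)/C(=C/c2cccc([N+](=O)[O-])c2)C1` differs from compound 2 in one place, with trifluoromethyl in place of chloro on an aromatic carbon. Among the measured compounds shown here, no measured pair isolates this change. Compound 1 also carries trifluoromethyl, differs elsewhere, and gives 6340 nM, so a modest move towards stronger inhibition is expected. The estimate implies an expected step of an at least 1.5-fold lower number from compound 2 to compound 3 (0.18 log units; that floor lies within the scatter). For compound 3 the estimated value is 13000 nM, with an expected range of 5000 nM to 30000 nM.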

Compound 3, half-maximal inhibitory concentration: 4780 nM
Beside the measured number, compound 3's estimate is 2.7-fold (0.43 log units) above it; measured number outside the range, below it.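

In this assay, trifluoromethyl in place of chloro on an aromatic carbon gives an at least 4.1-fold lower number from compound 2 to compound 3 (0.62 log units; beyond the scatter). That size is only a floor, as compound 2 carries a limit of the assay and not a number: the limit of > 20000 nM in this assay, at which 1 of the 3 values shown sits. With trifluoromethyl kept, 3-nitrophenyl in place of 2-fluorophenyl gives a 1.3-fold lower number from compound 1 to compound 3 (0.12 log units; within the scatter), so compound 1 and compound 3 cannot be told apart here.

The compounds shown hold only chloro and trifluoromethyl at this position, so how a methoxy group or an amine would fare there stays open. On these data alone, whether the swap gives a similar step alongside 2-fluorophenyl also stays open.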